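Cyanophenyl to pyrimidinyl on the sulfonyl sulfur

The source may hold more compounds than are shown below. What is called first, only, known or untested is meant among the compounds shown, and "the series" means these compounds.

Of the compounds shown here, three built on one shared core have been tested in a functional assay (Cavia porcellus) with sulfonylurea receptors; K-ATP channels (Homo sapiens) as the target; on this read-out higher numbers stand for weaker inhibition and lower numbers for stronger inhibition. Compound 1 `CC(O)(C(=O)Nc1ccc(S(=O)(=O)c2ccc(C#N)cc2)cc1)C(F)(F)F` gives in this assay > 30000 nM, which is a limit of the assay rather than a number. Compound 2 `CC(O)(C(=O)Nc1ccc(C(=O)c2cccc(F)c2)cc1)C(F)(F)F` gives in this assay 2600 nM. Compound 3 `CC(O)(C(=O)Nc1ccc(C(=O)c2ccccc2)cc1Cl)C(F)(F)F` gives in this assay > 30000 nM, again a limit rather than a measured number. Within the data shown here, compound 1 therefore stands at the limit of > 30000 nM in this assay, at which 2 of the 3 values shown sit, and there is no pair of measured compounds that differ in a single place, so no measured step can be used as a yardstick.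

The unmeasured compound 4 `CC(O)(C(=O)Nc1ccc(S(=O)(=O)c2cncnc2)cc1)C(F)(F)F` differs from compound 1 by pyrimidin-5-yl in place of 4-cyanophenyl on a sulfonyl sulfur. The step of a number no higher from compound 1 to compound 4 (the limit leaves the size open) is expected to be small, no larger than the usual scatter, in no clear direction. Compound 4 is accordingly expected to give about 30000 nM in this assay, with a range from 8000 nM to 100000 nM, and it may well come back as a limit once more.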

Compound 4, half-maximal inhibitory concentration: > 30000 nM
Compound 4 was reported as a limit; the forecaster's own chance of this, stated with the estimate: 65%; the middle value sits exactly at the limit.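

Among these compounds, compound 1 and compound 4 both come back from this assay as limits of the assay rather than numbers, so no step between them can be read. The compounds shown leave open whether pyrimidin-5-yl in place of 4-cyanophenyl on a sulfonyl sulfur changes inhibition at all.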